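The source may report more compounds than this note shows. Statements on the series, on what has been measured and on what is new or still open speak of the compounds shown alone.

Measured compounds:
compound 1 `CN1CCN(c2cc(C(F)(F)F)ccc2[C@H]2CCOc3cc(S(=O)(=O)Nc4nccs4)ccc32)CC1` — 2.1
compound 2 `Cc1nc(-c2cc(C(F)(F)F)ccc2[C@@H]2CCOc3cc(S(=O)(=O)Nc4nccs4)ccc32)co1` — 2.9
compound 3 `Cc1ccc(-c2cc(C(F)(F)F)ccc2[C@H]2CCOc3cc(S(=O)(=O)Nc4ccncn4)ccc32)cn1` — 3

In a physicochemical assay for lipophilicity (a lower number here means a more polar compound, a higher number a more lipophilic compound), compound 1 gives the lowest of the three numbers; compound 2 sits higher, by a gap beyond the scatter, and compound 3 higher still, also beyond the scatter. For the measured compounds named here, no pair of these three differs in a single place, so no step within the measured set is available.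

Compound 4 `O=S(=O)(Nc1nccs1)c1ccc2c(c1)OCC[C@@H]2c1ccc(C(F)(F)F)cc1-n1ccnn1` is not yet measured in this assay. Its structural change from compound 1 is counted as 1H-1,2,3-triazol-1-yl in place of 4-methylpiperazin-1-yl on an aromatic carbon

Against the three numbers in hand, the step is expected to go upward and to exceed the scatter, with compound 4 expected to land below compound 2 and compound 3. Compound 4 is estimated at 2.6 (range 2.1 to 3.1), a step of a number 0.50 log units higher from compound 1 to compound 4 (beyond the scatter).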

Compound 4, distribution coefficient: 2.3
For compound 4 the middle estimate is 0.30 log units above the measured one; measured number inside the range.
By their numbers in this assay, from the lowest: compounds 1 and 4 (each within the scatter of the next); then compounds 2 and 3 (each within the scatter of the next).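

In this assay, for the compounds shown here, 1H-1,2,3-triazol-1-yl in place of 4-methylpiperazin-1-yl, on an aromatic carbon ortho to a large group and meta to a trifluoromethyl group, gives a number 0.20 log units higher from compound 1 to compound 4 (within the scatter) as the first single-place comparison. At this position, then, a five-membered aromatic ring with 3 hetero atoms and a six-membered non-aromatic ring with 2 hetero atoms are not separated by this read-out. No available evidence bears on this result.

Compounds 2 and 3 differ from compound 1 in more than one place, so they add no comparison at this position. From the compounds shown here alone, how a carboxylic acid or a primary amine on the same carbon would read remains open.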